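Methoxyphenyl to Naphthyl Ester: Where the Limit Leaves Things

This account rests on a few compounds, and the source may have more. Where it says the series, first, only, none or still open, it means among the compounds named here.

Compound 3, `COc1ccc(OC(=O)c2cn(-c3ccccc3)nc2-c2ccncc2)cc1`, belongs to a small set of esters built on one shared core. In a functional assay on MDA-MB-231 cells (Homo sapiens) for cytotoxicity, read by MTT assay, with a stated time of 48 h (a higher number here means a weaker inhibitor, a lower number a stronger inhibitor), compound 3 gives only a limit, > 100000 nM. Compound 1, `COc1ccc(OC(=O)c2cn(-c3ccccc3)nc2-c2cccnc2)cc1`, likewise gives a limit, > 100000 nM. Compound 2, `O=C(Oc1ccc(-c2ccccc2)cc1)c1cn(-c2ccccc2)nc1-c1cccnc1`, also sits at a limit, > 100000 nM. the limit of > 100000 nM in this assay, at which 3 of the 3 values shown sit, marks where all three stand, so no measured number separates them. The step that the two limits leave unreadable from compound 1 to compound 2 is therefore unreadable, and so is a step that the two limits leave unreadable from compound 1 to compound 3; neither tells how far a change on the ester oxygen or on the pyridyl ring moves the read-out. Compound 4, `O=C(Oc1ccc2ccccc2c1)c1cn(-c2ccccc2)nc1-c1ccncc1`, differs from compound 3 by naphthalen-2-yl in place of 4-methoxyphenyl on an oxygen next to a carbonyl group. Neither measured step reads on this exchange: both are unreadable, and nothing in the set shows a move in either direction beyond the scatter. The expected step of a number no higher from compound 3 to compound 4 (the limit leaves the size open) is thus no more than a return to the same limit. Compound 4 is estimated at 100000 nM, between 30000 nM and 300000 nM, and is expected most likely to be reported again only as a limit.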

Compound 4, half-maximal inhibitory concentration: > 100000 nM
Compound 4: only a limit was reported (the forecaster's own chance of this, stated with the estimate: 75%); the middle value lies on the limit itself.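

No new step can be read between compound 3 and compound 4, since the exchange of 4-methoxyphenyl for naphthalen-2-yl ends at the same limit: the limit of > 100000 nM in this assay, at which 4 of the 4 values shown sit. In this assay the compounds shown leave open how strong each one is, and whether any of these exchanges moves the read-out at all.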